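The source may hold more compounds than are shown below. What is called first, only, known or untested is meant among the compounds shown, and "the series" means these compounds.

Measured in an ADME assay on HepG2 cells (Homo sapiens) for cytotoxicity, read by MTT assay; on this read-out lower numbers stand for stronger inhibition and higher numbers for weaker inhibition:
compound 1 `O=C(NCc1ccccc1)Oc1ccc(Cl)cc1C(=O)Nc1ccc(F)cc1`: > 125000 nM
compound 2 `O=C(NC1CCCCC1)Oc1ccc(Cl)cc1C(=O)Nc1ccc(Br)cc1`: > 50000 nM
compound 3 `O=C(Nc1ccccc1)Oc1ccc(Cl)cc1C(=O)Nc1ccc(Br)cc1`: > 50000 nM

All three entries are limits, so the series holds no numeric reading so far. Compound 3 stands at > 50000 nM, which is a limit and not a number. Compound 2 shares that position, (the limit of > 50000 nM in this assay, at which 2 of the 3 values shown sit).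

Compound 4 `O=C(NCc1ccccc1)Oc1ccc(Cl)cc1C(=O)Nc1ccc(Br)cc1` has not yet been measured. Its change from compound 3 is benzyl in place of phenyl on an amide-type nitrogen. In words, this is benzyl in place of phenyl on an amide-type nitrogen, or anilino to benzylamino.

Among the compounds with values here, the one measured step at this nitrogen is a step that the two limits leave unreadable from compound 2 to compound 3, so it offers no size to carry over. Compound 1 also carries benzyl on that nitrogen, and its entry is the limit of > 125000 nM in this assay, at which 1 of the 3 values shown sits, again only a limit.

No step beyond the scatter is therefore expected in this assay, and no direction can be assigned. The estimated change is a step that the limit leaves unreadable from compound 3 to compound 4, and it should be read as no real move. Compound 3 at > 50000 nM, a limit, anchors the expectation, and compound 4 is expected to be reported as a limit as well. The estimate for compound 4 is 60000 nM, with an expected range from 25000 nM to 150000 nM.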

Compound 4, half-maximal inhibitory concentration: > 50000 nM
Compound 4: a limit, no number; the forecaster's own chance of this, stated with the estimate: 85%; the middle value lies beyond the limit too.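

In this assay compound 4 gives > 50000 nM, a limit and not a number. All four entries are limits, and the steps from compound 1, compound 2 and compound 3 to compound 4 cannot be read. The compounds shown leave open whether benzyl, phenyl or cyclohexyl on the amide-type nitrogen, or bromo in place of fluoro, shifts the read-out at all in this assay.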